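The source may hold more compounds than are shown below. What is called first, only, known or untested is meant among the compounds shown, and "the series" means these compounds.

The measured compounds:
compound 1, `CCN(CC)c1c(C)n(-c2ccccc2)c(=O)n(C)c1=O`; in a physicochemical assay for lipophilicity (a lower number here means a more polar compound, a higher number a more lipophilic compound), compound 1 gives 2.19
compound 2, `CCN(CC)c1c(C)n(CC)c(=O)n(-c2ccccc2)c1=O`; in this assay compound 2 gives 2.2

Compound 1 stands lowest of the two numbers, but its nearest neighbour, compound 2, sits only a hair higher, within the scatter, so the two cannot be separated by this assay. Within the data shown here, no pair of measured compounds differs in just one place, so nothing among them shows how a change at the diethylamino group moves the partition coefficient.

Compound 3, `C=CCN(CC=C)c1c(C)n(-c2ccccc2)c(=O)n(C)c1=O`, differs from compound 1 in one place: diallylamino in place of diethylamino on an aromatic carbon. The group that enters is larger than the one that leaves and carries two double bonds outside aromatic rings, while donor and acceptor counts stay as they were.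

On that basis a modest upward step in this assay is expected, somewhat beyond the scatter, since the added carbon chain outweighs the unchanged acceptor. The step expected from compound 1 to compound 3 is a number 0.41 log units higher from compound 1 to compound 3 (beyond the scatter). Compound 3 is therefore estimated at 2.6, with a range from 2.3 to 2.9.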

Compound 3, partition coefficient: 2.59
Compound 3: the middle estimate sits 0.01 log units above what was measured; low and high end bracket the measured number.
By their numbers in this assay, from the lowest: compounds 1 and 2 (each within the scatter of the next); then compound 3.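

Among these compounds, compounds 1 and 3 form the first pair that differs only in the amino group on an aromatic carbon, so the earlier numbers could not show what they now show: the partition coefficient responds to a change at this position. In this assay, putting diallylamino in place of diethylamino gives a modest step, described as a number 0.40 log units higher from compound 1 to compound 3 (beyond the scatter). That step is clear of the noise that left compounds 1 and 2 unresolved. Nothing measured here accounts for the size of this step or says which feature of the entering group lies behind it.

The pair alone cannot separate the longer chains of diallylamino from its two double bonds, a question that dipropylamino, with saturated chains, would address, while a cyclic amine such as pyrrolidine or morpholine would test whether the response holds once the two chains are joined in a ring. Going by these compounds, it also remains open whether the same exchange would give a similar step on compound 2, where the phenyl group stands in a different place on the shared core.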